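A benzyl for cyclohexyl swap on the sulfonamide nitrogen

A few compounds are considered here, and "the series" means these few. Any claim that something is new, unique, unknown or untested is made for them only; others in the source may bear on it.

Compound 1, `CCCN(CCC)S(=O)(=O)NC(=O)Nc1c(C(C)C)cccc1C(C)C`, gives 1100 nM in an assay on liver for inhibition of sterol O-acyltransferase 1 (Rattus norvegicus), using microsomes; a higher number here means a weaker inhibitor, a lower number a stronger inhibitor.
Compound 2, `CC(C)c1cccc(C(C)C)c1NC(=O)NS(=O)(=O)N(C(C)C)C(C)(C)C`, gives 140 nM in this assay.
Compound 3, `CC(C)c1cccc(C(C)C)c1NC(=O)NS(=O)(=O)N(C(C)C)C1CCCCC1`, gives 360 nM in this assay.

Compound 3 stands second highest of the three numbers. It is nearest to compound 2, separated by the step of a 2.6-fold higher number from compound 2 to compound 3 (0.41 log units; beyond the scatter), and furthest from compound 1, whose number of 1100 nM lies above it.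

Compound 4, `CC(C)c1cccc(C(C)C)c1NC(=O)NS(=O)(=O)N(Cc1ccccc1)C(C)C`, differs from compound 3 in one place: benzyl in place of cyclohexyl on a sulfonamide nitrogen. Among the measured compounds shown here, two measured steps touch the same sulfonamide nitrogen. The first, a 7.9-fold lower number from compound 1 to compound 2 (0.90 log units; beyond the scatter), was modest; the second, a 2.6-fold higher number from compound 2 to compound 3 (0.41 log units; beyond the scatter), was also modest. Neither involves a benzyl group, so they bear on the new change only by showing that groups on this nitrogen shift this assay by modest amounts in either direction.

Compound 4 is therefore expected to stay close to compound 3, with an estimated step of a 1.1-fold higher number from compound 3 to compound 4 (0.05 log units; within the scatter) in this assay, likely within the scatter. The estimate for compound 4 in this assay is 400 nM, with a range from 150 nM to 1100 nM.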

Compound 4, half-maximal inhibitory concentration: 400 nM
Compound 4: the middle estimate sits on the measured number at the digits printed, within the range that was stated.
By their numbers in this assay, from the lowest: compound 2; then compounds 3 and 4 (each within the scatter of the next); then compound 1.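

Compound 3 and compound 4 cannot be told apart in this assay: the step is a 1.1-fold higher number from compound 3 to compound 4 (0.05 log units; within the scatter), so on this sulfonamide nitrogen an aromatic six-membered ring carried by benzyl reads the same as the non-aromatic ring of cyclohexyl. Tert-butyl still holds the lower number against benzyl, at a 2.9-fold higher number from compound 2 to compound 4 (0.46 log units; beyond the scatter), which matches its lower number against cyclohexyl and leaves compound 2 lowest among the groups paired with isopropyl on this nitrogen. Nothing measured here explains these numbers.

From the compounds shown here alone, it remains open whether a longer chain such as phenethyl in place of benzyl would separate from compound 4. The same holds for a benzyl ring carrying a carboxylic acid or an amine, and for a partner other than isopropyl on this nitrogen.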